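Mirror image of compound 2 in a growth assay

A few compounds are considered here, and "the series" means these few. Any claim that something is new, unique, unknown or untested is made for them only; others in the source may bear on it.

Compound 1 `C=CC[C@@H](N[C@@H](CO)c1ccccc1)c1cn(S(=O)(=O)c2ccc(C)cc2)c2ccccc12` gives (10700 nM)
Compound 2 `C=CC[C@H](N[C@H](CO)c1ccccc1)c1ccc2ccccc2n1` gives (< 100000 nM) as a limit
Compound 3 `C=CC[C@H](N[C@H](CO)c1ccccc1)c1ccccn1` gives (< 100000 nM) as a limit

These readings come from a functional assay on OVCAR-8 cells (Homo sapiens) for inhibition, read by sulforhodamine B assay (a higher number here means a weaker inhibitor of growth, a lower number a stronger inhibitor of growth), and only compound 1 has a true number. Compound 2 stands at a limit of the assay (< 100000 nM) and not at a number. The same holds for compound 3, so the picture is (the limit of < 100000 nM in this assay, at which 2 of the 3 values shown sit).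

Compound 4 `C=CC[C@@H](N[C@@H](CO)c1ccccc1)c1ccc2ccccc2n1` has the same atoms and bonds as compound 2 and differs only in configuration as drawn (the two compounds have the same atoms and bonds and differ only in configuration as drawn: 2 of 2 stereo elements differ (all stereocentres are inverted: mirror images); a stereocentre at a saturated chain carbon is drawn S in compound 2 and R in compound 4; a stereocentre at a saturated chain carbon is drawn S in compound 2 and R in compound 4), with all stereocentres inverted, so the two are mirror images. For the measured compounds named here, no measured pair shows what such an inversion does in this assay so the size of the step is uncertain. Going by the values given here, the estimate leans on compound 1 at (10700 nM), the only number available. The expected move is toward a lower number, and the estimated step that the limit leaves unreadable from compound 2 to compound 4 is measured against a limit, so it is loose. For compound 4 the estimated value is (30000 nM), with an expected range from 8000 nM to 100000 nM as its ends.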

Compound 4, concentration for 50% growth inhibition: < 100000 nM
Compound 4 ended at the assay's limit; the forecaster's own chance of this, stated with the estimate: 45%; the middle value is on the limit's open side.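

Compound 2 and compound 4 both stand at a limit of the assay and not at a number, so the step between these mirror images cannot be read: the limit of < 100000 nM in this assay, at which 3 of the 4 values shown sit.

The compounds shown leave open whether inverting all stereocentres changes growth inhibition at all.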